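Methylsulfonyl for phenylcarbamoyl on the ring amine

The compounds below may be only part of what the source reports. "The series", "measured", "known", "first", "only" and "open" are said of these compounds alone.

Measured so far:
compound 1 `O=[N+]([O-])c1ccc(CN(Cc2ccc(Cl)cc2)Cc2nc3ccccc3s2)s1`, 4000 nM in a functional assay on HEK293 cells for agonist activity at nuclear receptor subfamily 1 group D member 1 (Homo sapiens), read by a luciferase reporter, with a stated time of 24 h; a higher number here means that more compound is needed for the effect, a lower number that less compound is needed
compound 2 `O=C(Nc1ccccc1)N1CCC(CN(Cc2ccc(Cl)cc2)Cc2ccc([N+](=O)[O-])s2)C1`, 620 nM in this assay

Compound 2 stands lowest of the two numbers; its nearest neighbour, compound 1, sits higher by a margin beyond the usual scatter. The two differ in more than one place, so nothing beyond their two values is read from that pair. Compound 3 `CS(=O)(=O)N1CCC(CN(Cc2ccc(Cl)cc2)Cc2ccc([N+](=O)[O-])s2)C1` keeps the core of compound 2 and changes one place: methylsulfonyl in place of phenylcarbamoyl on an amine nitrogen in a ring. Within the data shown here, no step between measured compounds covers this change, so the direction has to be judged from the structures alone. With the group of more heavy atoms leaving and a small one entering, the expected step from compound 2 to compound 3 in this assay is moderate and toward a higher number, a 3.2-fold higher number from compound 2 to compound 3 (0.51 log units; beyond the scatter). Compound 3 is estimated at 2000 nM in this assay, with a range of 600 nM to 7000 nM.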

Compound 3, half-maximal effective concentration: 570 nM
For compound 3 the middle estimate is 3.5-fold (0.55 log units) above the measured one; the whole stated range lies above it.
By their numbers in this assay, from the lowest: compounds 3 and 2 (each within the scatter of the next); then compound 1.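

On the amine nitrogen in the five-membered non-aromatic ring, methylsulfonyl with its 4 heavy atoms and phenylcarbamoyl with its 9 cannot be told apart in this assay (a 1.1-fold lower number from compound 2 to compound 3 (0.04 log units; within the scatter)). At this place, then, neither the six-membered aromatic ring nor the hydrogen-bond donor of phenylcarbamoyl is needed to hold a value in this range. The lower number relative to the benzothiazole-bearing compound also persists with methylsulfonyl on the ring amine (1-(methylsulfonyl)pyrrolidin-3-yl in place of 1,3-benzothiazol-2-yl, a 7.0-fold lower number from compound 1 to compound 3 (0.85 log units; beyond the scatter)), and no measurement shown explains either step.

Whether this ring nitrogen needs any substituent remains open, as the compounds shown include neither the free amine nor a simple acetyl group there. Nor do they show how far the sulfonyl group tolerates growth, for instance to ethylsulfonyl or phenylsulfonyl.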